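This account rests on a few compounds, and the source may have more. Where it says the series, first, only, none or still open, it means among the compounds named here.

Measured so far in an assay on HEK293 cells for inhibition of acid ceramidase (Homo sapiens), read by fluorescence, with stated times of 30 min and 1 h; a lower number here means a stronger inhibitor, a higher number a weaker inhibitor:
Compound 1 `O=C(NCCCCc1ccccc1)n1nnc2ccccc21` gives 2.1 nM.
Compound 3 `CCCCCCNC(=O)n1nnc2ccccc21` gives 4.1 nM.
Compound 2 `O=C(NCCCCc1ccccc1)Nc1nc2ccccc2[nH]1` reaches only the limit of this assay, > 10000 nM.

Compound 1 and compound 3 share one core, and the change between them is ethyl in place of phenyl on a saturated chain carbon, four bonds along the chain from an amide-type nitrogen. In this assay that change made a 2.0-fold higher number from compound 1 to compound 3 (0.29 log units; within the scatter). Compound 2 carries a different core; the difference between the two cores is not broken down here. Compound 2 sits at the limit of > 10000 nM in this assay, at which 1 of the 3 values shown sits.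

Compound 4 `CCCCCCNC(=O)Nc1nc2ccccc2[nH]1` is not yet measured. It stands to compound 2 as compound 3 stands to compound 1, the change being (ethyl in place of phenyl on a saturated chain carbon, four bonds along the chain from an amide-type nitrogen), and the place of the change is the same in both pairs. On the measured pair the change stayed within the scatter, so from compound 2 the expected step is a step that the limit leaves unreadable from compound 2 to compound 4, which rests on the step of a 2.0-fold higher number from compound 1 to compound 3 (0.29 log units; within the scatter) and on the limit reached by compound 2. Compound 4 is therefore expected at 15000 nM, between 7000 nM and 60000 nM, most probably reported again only as a limit of this assay.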

Compound 4, half-maximal inhibitory concentration: > 10000 nM
Compound 4 ended at the assay's limit; the forecaster's own chance of this, stated with the estimate: 85%; the middle value does not contradict the limit.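

No new step can be read from compound 2 to compound 4, as both values are limits and not numbers: the limit of > 10000 nM in this assay, at which 2 of the 4 values shown sit. The compounds shown leave open how large the change from phenyl to ethyl is on the core of compound 2, and what the actual values of these two compounds are.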